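Adding one more chloro to compound 3

The source may report more compounds than this note shows. Statements on the series, on what has been measured and on what is new or still open speak of the compounds shown alone.

Measured in an ADME assay on BHK-21 cells (Mesocricetus auratus) for cytotoxicity, read by MTT assay, with a stated time of 96 h (a higher number here means that more compound is tolerated, a lower number that less compound is tolerated), all as limits:
Compound 1 `Clc1cccc(/N=N/N2CCCC2)c1` gives > 100000 nM
Compound 2 `c1ccc(/N=N/N2CCCC2)cc1` gives >= 100000 nM
Compound 3 `Clc1ccc(/N=N/N2CCCC2)cc1` gives > 100000 nM

None of these three entries is a number. Compound 3 stands at > 100000 nM, which is a limit of this assay. The same limit appears for compound 1, so the set reads (the limit of > 100000 nM in this assay, at which 2 of the 3 values shown sit). The remaining entry belongs to the limit of >= 100000 nM in this assay, at which 1 of the 3 values shown sits.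

Compound 4 `Clc1ccc(/N=N/N2CCCC2)cc1Cl` differs from compound 3 in one place: chloro in place of hydrogen on an aromatic carbon. The new chloro sits ortho to a chloro group and meta to a group of 7 heavy atoms.

Among the measured compounds shown here, two measured steps bear on this change, both exchanges of hydrogen and chloro on an aromatic carbon. For the measured compounds named here, the first is a step that the two limits leave unreadable from compound 1 to compound 2. The second is a step that the two limits leave unreadable from compound 2 to compound 3. Going by the values given here, neither gives a size, and no chloro compound here has left the limit.

No step beyond the scatter is therefore expected, though this rests on limits alone. The expectation starts from the limit of compound 3, > 100000 nM. The expected step is a number no higher from compound 3 to compound 4 (the limit leaves the size open). For compound 4 the estimate is 100000 nM, with an expected range from 40000 nM to 150000 nM.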

Compound 4, half-maximal cytotoxic concentration: 50000 nM
Beside the measured number, compound 4's estimate is 2.0-fold (0.30 log units) above it, within the range that was stated.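

In this assay, compound 4 gives 50000 nM, the only entry here that is a number and not a limit, so the chloro ortho to a chloro group and meta to a group of 7 heavy atoms supplies the first readable point in this set. The change itself gives an at least 2.0-fold lower number from compound 3 to compound 4 (0.30 log units; that floor lies within the scatter), and the comparison with the other compound that carries a single chloro gives an at least 2.0-fold lower number from compound 1 to compound 4 (0.30 log units; that floor lies within the scatter). Both are floors with a limit on one side, so neither shows a step beyond the scatter, and the steps among the three earlier compounds cannot be read, as those entries stay at limits: the limit of > 100000 nM in this assay, at which 2 of the 4 values shown sit.

From the compounds shown here alone, the true size of the step from the limit of compound 3 stays open, since only its floor can be read. Also open, going by these compounds, is whether the reading of compound 4 is particular to chloro, a question that a methoxy group or a carboxylic acid at this same place, ortho to the chloro group, would bear on.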